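Compound 1 to compound 3: cyano exchange, working notes

The compounds below may be only part of what the source reports. "The series", "measured", "known", "first", "only" and "open" are said of these compounds alone.

- compound 1 `CC(=O)CCc1cc(C)c(Oc2cc(Nc3ccc(C#N)cc3)c(N)cc2C(F)(F)F)c(C)c1` at 11100 nM
- compound 2 `CNC(=O)c1cc(N)c(Nc2ccc(C#N)cc2)cc1Oc1c(C)cc(CCC#N)cc1C` at > 9100 nM which is a limit

Among the compounds with values here, in an ADME assay on TZM cells (Homo sapiens) for cytotoxicity, read by XTT assay, with a stated time of 4 days (on this read-out lower numbers stand for higher toxicity in this test and higher numbers for lower toxicity in this test), compound 1 gives 11100 nM as the only exact number so far. Compound 2 stands at > 9100 nM which is a limit. Compound 3 `Cc1cc(C#N)cc(C)c1Oc1cc(Nc2ccc(C#N)cc2)c(N)cc1C(F)(F)F` differs from compound 1 by cyano in place of 2-acetylethyl on an aromatic carbon with the rest of the core unchanged. Within the data shown here, no measured step bears on this change, so the reference remains compound 1 at 11100 nM and no shift beyond the scatter is expected in this assay in either direction. The estimated 1.1-fold higher number from compound 1 to compound 3 (0.03 log units; within the scatter) is accordingly small. Compound 3 is expected at 12000 nM with an estimated range from 4000 nM to 35000 nM as the working figure.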

Compound 3, half-maximal cytotoxic concentration: 13300 nM
Compound 3: the middle estimate sits 1.1-fold (0.04 log units) below what was measured; measured number inside the range.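

In this assay this aromatic carbon now has a measured step for cyano in place of 2-acetylethyl (with a 1.2-fold higher number from compound 1 to compound 3 (0.08 log units; within the scatter)). The exchange of the longer chain for the two-atom cyano therefore leaves the read-out within the scatter on the shared core. Nothing at hand points to a cause for this result.

On these data alone, whether an amine, a carboxylic acid or a longer chain at this position would also stay within the scatter remains open. So does whether the same exchange holds with another group in place of trifluoromethyl.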